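A few compounds are considered here, and "the series" means these few. Any claim that something is new, unique, unknown or untested is made for them only; others in the source may bear on it.

Measured compounds:
Compound 1, `FC(F)(F)c1cc(COC[C@@H](NCc2nc[nH]n2)c2ccccc2)cc(C(F)(F)F)c1`, gives 5 nM in an assay on CHO cells for displacement of a labelled ligand from Substance-P receptor (Homo sapiens); a higher number here means a weaker inhibitor, a lower number a stronger inhibitor.
Compound 2, `CN(Cc1nc[nH]n1)[C@H](COCc1cc(C(F)(F)F)cc(C(F)(F)F)c1)c1ccccc1`, gives 1.4 nM in this assay.

Among the measured compounds shown here, compound 2 stands at the lowest of the two numbers so far; its nearest neighbour is compound 1, and the step of a 3.6-fold lower number from compound 1 to compound 2 (0.55 log units; beyond the scatter) set it apart by a margin beyond the scatter, so compound 2 is the stronger inhibitor of the two.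

Compound 3, `Oc1n[nH]c(CN[C@H](COCc2cc(C(F)(F)F)cc(C(F)(F)F)c2)c2ccccc2)n1`, has not yet been measured in this assay. It differs from compound 2 by ((3-hydroxy-1H-1,2,4-triazol-5-yl)methyl)amino in place of ((1H-1,2,4-triazol-3-yl)methyl)(methyl)amino on a saturated chain carbon bound to an aromatic carbon and a saturated chain carbon. For the measured compounds named here, two things change at once: the methyl on the amine nitrogen goes, which reverses the single measured step, and a hydroxy enters on the triazole, for which no measured step exists. Reversing the step of a 3.6-fold lower number from compound 1 to compound 2 (0.55 log units; beyond the scatter) would return the number to roughly that of compound 1. Going by the values given here, nothing among the measured compounds shows what the hydroxy on the triazole does, so the expectation rests on the removal of the methyl alone, with a wider range to cover the untested hydroxy. Compound 3 is therefore expected to give about 5 nM in this assay, within roughly 1.5 nM to 20 nM. The step from compound 2 to compound 3 is estimated as a 3.6-fold higher number from compound 2 to compound 3 (0.55 log units; beyond the scatter), a weakening of modest size.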

Compound 3, half-maximal inhibitory concentration: 2.4 nM
The estimate for compound 3 lay 2.1-fold (0.32 log units) above the measured number; low and high end bracket the measured number.
By their numbers in this assay, from the lowest: compounds 2 and 3 (each within the scatter of the next); then compound 1.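

Among the compounds shown here, with the amine nitrogen left as in compound 1, the hydroxy on the triazole brought the first measured change at this ring: 3-hydroxy-1H-1,2,4-triazol-5-yl in place of 1H-1,2,4-triazol-3-yl gave a 2.1-fold lower number from compound 1 to compound 3 (0.32 log units; beyond the scatter) in this assay. This modest step runs in the same direction as the one seen with the methyl on the amine nitrogen, a 3.6-fold lower number from compound 1 to compound 2 (0.55 log units; beyond the scatter), and exchanging one change for the other gave a 1.7-fold higher number from compound 2 to compound 3 (0.23 log units; within the scatter), so either change on compound 1 leads to a number that the scatter does not separate from the other. No supporting evidence is available to explain why the hydroxy shifts the number in this way.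

The compounds shown leave open whether the hydroxy on the triazole and the methyl on the amine nitrogen would add up if both stood on one compound. They also leave open whether the shift is particular to the hydroxy or would also appear with an amino group or a methoxy on the triazole, and what an ethyl on the amine nitrogen would do.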